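Phenylcarbamoyl for vinylsulfonyl on the ring amine

The compounds below may be only part of what the source reports. "The series", "measured", "known", "first", "only" and "open" are said of these compounds alone.

In a functional assay on MDA-MB-436 cells (Homo sapiens) for antiproliferative activity, read by MTT assay, with a stated time of 48 h (a higher number here means a weaker inhibitor, a lower number a stronger inhibitor), compound 1 `C=CS(=O)(=O)N1CCN(c2ncnc3sc(-c4ccc(C(F)(F)F)cc4)cc23)CC1` gives 7080 nM, compound 2 `C=CS(=O)(=O)N1CCN(c2ncnc3sc(-c4ccc(C#N)cc4)cc23)CC1` gives 9170 nM and compound 3 `C=CS(=O)(=O)N1CCN(c2ncnc3sc(-c4ccc(N5CCN(C)CC5)cc4)cc23)CC1` gives 8760 nM. Compound 3 therefore stands within the scatter of both other compounds, and the three form a single group on these numbers.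

Compound 4 `CN1CCN(c2ccc(-c3cc4c(N5CCN(C(=O)Nc6ccccc6)CC5)ncnc4s3)cc2)CC1` keeps the 4-methylpiperazin-1-yl group of compound 3 and carries phenylcarbamoyl in place of vinylsulfonyl on an amine nitrogen in a ring.

The measured steps bear on this change only indirectly. They are a 1.3-fold higher number from compound 1 to compound 2 (0.11 log units; within the scatter), a 1.2-fold higher number from compound 1 to compound 3 (0.09 log units; within the scatter) and a 1.0-fold lower number from compound 2 to compound 3 (0.02 log units; within the scatter). All three concern the group on an aromatic carbon, and all lie within the scatter. Among the compounds with values here, all three measured compounds carry vinylsulfonyl, so no measured step shows what replacing it does in this assay. The data favour no direction, and no step beyond the scatter is expected, although the uncertainty is large for a change of this size. The expected step is a 1.0-fold higher number from compound 3 to compound 4 (0.01 log units; within the scatter), and the range is kept wide on both sides. The estimated value for compound 4 is 9000 nM, with an expected range from 3000 nM to 30000 nM.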

Compound 4, half-maximal inhibitory concentration: 7090 nM
Compound 4: the middle estimate sits 1.3-fold (0.10 log units) above what was measured, and the stated range covers the measured number.
By their numbers in this assay, from the lowest: compounds 1, 4, 3 and 2 (each within the scatter of the next).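

In this assay, within the data shown here, the step at the amine nitrogen in a ring is a 1.2-fold lower number from compound 3 to compound 4 (0.09 log units; within the scatter), the first measured reading of any replacement of vinylsulfonyl. With the 4-methylpiperazin-1-yl group held constant, this pair shows that vinylsulfonyl is not required for a number in this range, since phenylcarbamoyl, with its six-membered aromatic ring of carbon only and its hydrogen-bond donor, stays within the scatter of compound 3. Nothing available on the compounds gives a reason for this result.

The compounds shown leave open whether the same swap holds when trifluoromethyl or cyano takes the place of 4-methylpiperazin-1-yl on the aromatic carbon, as phenylcarbamoyl is seen here with only one such partner. They also leave open whether any group on this ring nitrogen can move the number beyond the scatter, for example a small acetyl group, a methylsulfonyl group, or a phenylcarbamoyl whose aromatic ring carries a carboxylic acid or an amine.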